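Ethyl Added to the Side Chain: Solubility Expected to Hold

A few compounds are considered here, and "the series" means these few. Any claim that something is new, unique, unknown or untested is made for them only; others in the source may bear on it.

The study follows three measured compounds and one unmeasured compound in a physicochemical assay for solubility, at pH 7.4; on this read-out lower numbers stand for lower solubility and higher numbers for higher solubility. Compound 1, `C[C@@H]1[C@@H](NC(=O)[C@@H](C)N)CN1c1nc2c(cc1F)c(=O)c(C(=O)O)cn2C1CC1`, is reported at a limit of this assay rather than at a number: compound 1 gives > 500 ug/mL. Compound 2, `CC(C)C[C@H](N)C(=O)N[C@@H]1CN(c2nc3c(cc2F)c(=O)c(C(=O)O)cn3C2CC2)[C@H]1C`, likewise reaches a limit, with compound 2 giving > 500 ug/mL. Compound 3, `C[C@H](N)C(=O)N[C@@H]1CN(c2cc3c(cc2F)c(=O)c(C(=O)O)cn3-c2ccc(F)cc2F)[C@H]1C`, is the starting point of the step considered here, and in this assay compound 3 also gives only a limit, > 500 ug/mL. For the measured compounds named here, all three values thus stand at the same place, (the limit of > 500 ug/mL in this assay, at which 3 of the 3 values shown sit), so nothing in the measured set separates them and no step between them can be stated.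

Compound 4, `CCC[C@H](N)C(=O)N[C@@H]1CN(c2cc3c(cc2F)c(=O)c(C(=O)O)cn3-c2ccc(F)cc2F)[C@H]1C`, differs from compound 3 in one place: ethyl in place of hydrogen on a saturated chain carbon, two bonds along the chain from an amine nitrogen and a carbonyl carbon. Going by the values given here, no measured pair mirrors this change, so its direction cannot be read from data. The three measured compounds, which differ among themselves at more than one place, all sit at the limit, so the expectation is that the step of a number no higher from compound 3 to compound 4 (the limit leaves the size open) stays within the scatter, with no clear direction. Compound 4 is therefore expected at an estimated 500 ug/mL, within a range from 200 ug/mL to 900 ug/mL, with a fair chance that only a limit is reported again.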

Compound 4, solubility: > 500 ug/mL
Compound 4 gave a limit, no number (the forecaster's own chance of this, stated with the estimate: 65%); the middle value sits exactly at the limit.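

In this assay compound 4 gives only a limit, > 500 ug/mL. With compound 3 also reported as a limit, no step from compound 3 to compound 4 can be read, and the measured set remains undivided: the limit of > 500 ug/mL in this assay, at which 4 of the 4 values shown sit.

The compounds shown leave open where all four truly lie in this assay, and whether ethyl in place of hydrogen changes the read-out at all.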